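Second ester on the acid of compound 1: stability outlook

The source may hold more compounds than are shown below. What is called first, only, known or untested is meant among the compounds shown, and "the series" means these compounds.

Measured in an ADME assay for metabolic stability, read by LC-MS, with a stated time of 3 h, at pH 6.5, tested at 50 uM; on this read-out lower numbers stand for a less stable compound and higher numbers for a more stable compound:
- compound 1 `C[C@@H](O)[C@H]1C(=O)N2C(C(=O)OCOC(=O)C3CCCCC3)=C(S[C@@H]3CN[C@H](C(=O)Nc4cccc(C(=O)O)c4)C3)[C@H](C)[C@H]12` gives > 95%, a limit of the assay.
- compound 2 `CCC(CC)C(=O)OCOC(=O)C1=C(S[C@@H]2CN[C@H](C(=O)Nc3cccc(C(=O)O)c3)C2)[C@H](C)[C@@H]2[C@@H]([C@@H](C)O)C(=O)N12` gives > 95%, a limit of the assay.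

Compound 1 stands at the limit of > 95% in this assay, at which 2 of the 2 values shown sit. Among the measured compounds shown here, the one measured step, a step that the two limits leave unreadable from compound 1 to compound 2, is therefore unreadable in size and direction.

Compound 3 `C[C@@H](O)[C@H]1C(=O)N2C(C(=O)OCOC(=O)C3CCCCC3)=C(S[C@@H]3CN[C@H](C(=O)Nc4cccc(C(=O)OCOC(=O)C5CCCCC5)c4)C3)[C@H](C)[C@H]12` differs from compound 1 by ((cyclohexylcarbonyl)oxy)methyl in place of hydrogen on an oxygen next to a carbonyl group. For the measured compounds named here, no measured step covers this change, and the two limits give no size to lean on. Compound 3 is expected to stay near the limit, the step of a number at least 5 percentage points lower from compound 1 to compound 3 (that floor lies within the scatter) being an estimate only. The estimate for compound 3 in this assay is 90%, ranging from 70% to 98%.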

Compound 3, percent of the compound remaining: > 95%
Compound 3: no number, only a limit; the forecaster's own chance of this, stated with the estimate: 50%; at least 5 percentage points between middle value and limit.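

In this assay, no step can be read from compound 1 to compound 3, as both values are limits: the limit of > 95% in this assay, at which 3 of the 3 values shown sit.

As far as these compounds go, whether ((cyclohexylcarbonyl)oxy)methyl in place of hydrogen changes stability at all remains open, as does any ranking of compound 1, compound 2 and compound 3.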